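The source may report more compounds than this note shows. Statements on the series, on what has been measured and on what is new or still open speak of the compounds shown alone.

Compound 2 `C=C1C(=O)O[C@H]2CC3=C[C@H](C/C(C)=C/[C@@H](OC(=O)/C=C/c4cccc(OC)c4)[C@H]12)OC3=O` carries a 2-(3-methoxyphenyl)ethenyl ester on the shared core. In a functional assay on NCI-H460 cells (Homo sapiens) for cytotoxicity, read by MTT assay, with a stated time of 48 h (a higher number here means a weaker inhibitor, a lower number a stronger inhibitor), compound 2 reaches only a limit of the assay, > 10000 nM. Compound 1 `C=C1C(=O)O[C@H]2CC3=C[C@H](C/C(C)=C/[C@@H](OC(=O)c4ccc([N+](=O)[O-])cc4)[C@H]12)OC3=O`, with a 4-nitrophenyl ester, likewise stops at a limit, > 10000 nM. Compound 3 `C=C1C(=O)O[C@H]2CC3=C[C@H](C/C(C)=C/[C@@H](OC(=O)C(C)(C)CC)[C@H]12)OC3=O`, bearing a 1,1-dimethylpropyl ester, gives 6100 nM in this assay, so that an at least 1.6-fold lower number from compound 2 to compound 3 (0.21 log units; that floor lies within the scatter) and an at least 1.6-fold lower number from compound 1 to compound 3 (0.21 log units; that floor lies within the scatter), while a step that the two limits leave unreadable from compound 1 to compound 2. Two of the three values sit at the limit of > 10000 nM in this assay, at which 2 of the 3 values shown sit. Compound 4 `C=C1C(=O)O[C@H]2CC3=C[C@H](C/C(C)=C/[C@@H](OC(=O)c4ccncc4)[C@H]12)OC3=O` differs from compound 2 as follows: pyridin-4-yl in place of 2-(3-methoxyphenyl)ethenyl on a carbonyl carbon. For the measured compounds named here, no measured step covers an exchange between two aromatic esters; the only readable steps move toward an alkyl ester. Compound 4 is therefore expected to stay near the limit, with an at least 1.1-fold lower number from compound 2 to compound 4 (0.04 log units; that floor lies within the scatter) and an estimate of 9000 nM, ranging from 3000 nM to 30000 nM.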

Compound 4, half-maximal inhibitory concentration: 5600 nM
Estimate against measurement, compound 4: 1.6-fold (0.21 log units) above, and the stated range covers the measured number.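

At this position, on a carbonyl carbon, an aromatic ester now gives a measured number in this assay: pyridin-4-yl brings an at least 1.7-fold lower number from compound 2 to compound 4 (0.25 log units; that floor lies within the scatter) and an at least 1.7-fold lower number from compound 1 to compound 4 (0.25 log units; that floor lies within the scatter). Against the alkyl ester, the exchange gives a 1.1-fold lower number from compound 3 to compound 4 (0.04 log units; within the scatter), so pyridin-4-yl and 1,1-dimethylpropyl cannot be told apart here. Limits remain among the values: the limit of > 10000 nM in this assay, at which 2 of the 4 values shown sit.

The compounds shown leave open how an ester carrying an amine or a carboxylic acid, or a longer alkyl chain, would read. They also leave open whether any ester at this place can stand beyond the scatter from compound 3 and compound 4.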